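Three purine analogues in a rat antagonist assay

This account rests on a few compounds, and the source may have more. Where it says the series, first, only, none or still open, it means among the compounds named here.

Measured so far:
compound 1 `CCCn1cnc2c(N(C)C)ncnc21` gives 14 mg/kg
compound 2 `CN(C)c1ncnc2c1ncn2C1CCC1` gives 11 mg/kg
compound 3 `c1nc(NC2CC2)c2ncn(C3CCC3)c2n1` gives 19 mg/kg

All three were tested in a functional assay on the whole organism for antagonist activity, with Rattus norvegicus as the target; on this read-out lower numbers stand for an effect already at smaller amounts and higher numbers for an effect only at larger amounts of compound. Compound 2 serves as the point of comparison. Its relation to compound 1 is the change (propyl in place of cyclobutyl on an aromatic nitrogen), and that step amounts to a 1.3-fold higher number from compound 2 to compound 1 (0.10 log units; within the scatter). Its relation to compound 3 is a change at a different position, (cyclopropylamino in place of dimethylamino on an aromatic carbon), and that step amounts to a 1.7-fold higher number from compound 2 to compound 3 (0.24 log units; within the scatter). Compound 1 and compound 3 share neither change, so only their two values can be set side by side, and these lie within the scatter of each other. None of the three can be called more or less potent than another on this evidence.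

Compound 4 `CCCn1cnc2c(NC3CC3)ncnc21` has not yet been measured in this assay. It differs from compound 3 by propyl in place of cyclobutyl on an aromatic nitrogen. Within the data shown here, this is the same change as the one from compound 2 to compound 1, made here on a core that already carries the cyclopropylamino group instead of the dimethylamino group. Because a 1.3-fold higher number from compound 2 to compound 1 (0.10 log units; within the scatter) was within the scatter, the same change is expected to leave the value of compound 3 essentially unchanged, giving an expected step of a 1.3-fold higher number from compound 3 to compound 4 (0.10 log units; within the scatter). For compound 4 the estimate in this assay is 24 mg/kg, with an expected range from 12 mg/kg to 48 mg/kg.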

Compound 4, dose for half-maximal effect: 6 mg/kg
The estimate for compound 4 lay 4.0-fold (0.60 log units) above the measured number; measured number below the stated range.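

Propyl in place of cyclobutyl on an aromatic nitrogen does not act alike on the two cores in this assay and, with cyclopropylamino on the core, it brings a real fall in the dose needed (a 3.2-fold lower number from compound 3 to compound 4 (0.50 log units; beyond the scatter)) that stands apart from the earlier step: the same change on two cores in this assay, a 1.3-fold higher number (0.10 log units; within the scatter) from compound 2 to compound 1 and a 3.2-fold lower number (0.50 log units; beyond the scatter) from compound 3 to compound 4, 4.0-fold (0.61 log units) apart, beyond the scatter of two such steps.

Seen from the other side, cyclopropylamino in place of dimethylamino on an aromatic carbon also brings a fall once propyl is present (a 2.3-fold lower number from compound 1 to compound 4 (0.37 log units; beyond the scatter)) and likewise differs from its earlier step: the same change on two cores in this assay, a 1.7-fold higher number (0.24 log units; within the scatter) from compound 2 to compound 3 and a 2.3-fold lower number (0.37 log units; beyond the scatter) from compound 1 to compound 4, 4.0-fold (0.61 log units) apart, beyond the scatter of two such steps.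

These two comparisons rest on the same four compounds and are one finding seen from two sides: in this small set the two changes do not simply add up, so a step measured on one core cannot safely be carried to another, but the data do not show why this happens or how widely it applies.

Among these compounds, the finding hangs on the single result for compound 4, so a repeat measurement would add weight to it. On these data alone, it also remains open whether a longer chain such as butyl on the aromatic nitrogen, or an ethylamino group on the aromatic carbon, would show the same dependence on its partner group.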